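Working notes: one aryl swap on the shared core

The source may hold more compounds than are shown below. What is called first, only, known or untested is meant among the compounds shown, and "the series" means these compounds.

compound 1 `OC(c1ccc(Cl)cc1)(c1cncnc1)c1cccc(F)c1` gives > 100000 nM
compound 2 `OC(c1ccc(Cl)cc1)(c1cccnc1)c1ccccc1Cl` gives 61300 nM
compound 3 `OC(c1ccc(Cl)cc1)(c1cccnc1)c1cccc(F)c1` gives 66000 nM

In an ADME assay on L6 cells (Rattus norvegicus) for cytotoxicity, read by resazurin assay, with a stated time of 72 h (a higher number here means a weaker inhibitor, a lower number a stronger inhibitor), compound 1 gives > 100000 nM as a limit of the assay and not a number. Compound 3 gives 66000 nM and shares its level with compound 2 (a 1.1-fold higher number from compound 2 to compound 3 (0.03 log units; within the scatter)). Compound 4 `Cc1ccccc1C(O)(c1ccc(Cl)cc1)c1cccnc1` carries 2-methylphenyl in place of 3-fluorophenyl on a saturated chain carbon bound to two aromatic carbons and an oxygen on a saturated carbon. The closest measured evidence is the exchange at this same place between compound 2 and compound 3 (a 1.1-fold higher number from compound 2 to compound 3 (0.03 log units; within the scatter)), which moved nothing beyond the scatter. The other step (an at least 1.5-fold lower number from compound 1 to compound 3 (0.18 log units; that floor lies within the scatter)) concerns a different group and gives no size beyond the scatter either. No step beyond the scatter is therefore expected in this assay, and no direction can be assigned. The expected step (a 1.1-fold lower number from compound 3 to compound 4 (0.04 log units; within the scatter)) is correspondingly small. Compound 4 is expected at 60000 nM with an estimated range of 30000 nM to 100000 nM for this measurement.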

Compound 4, half-maximal inhibitory concentration: 82000 nM
The estimate for compound 4 lay 1.4-fold (0.14 log units) below the measured number, within the range that was stated.
By their numbers in this assay, from the lowest: compounds 2, 3 and 4 (each within the scatter of the next). At a limit, above all of these: compound 1.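

Replacing 3-fluorophenyl with 2-methylphenyl on the saturated chain carbon gives a 1.2-fold higher number from compound 3 to compound 4 (0.09 log units; within the scatter) in this assay, and methyl in place of chloro on an aromatic carbon gives a 1.3-fold higher number from compound 2 to compound 4 (0.13 log units; within the scatter). Compound 4 extends this position to an aryl group carrying no halogen, and it reads the same as compound 2 and compound 3 within the scatter. With pyridin-3-yl held constant, none of the three aryl groups shown separates from the others in this assay.

As far as these compounds go, whether an amine or a carboxylic acid on this aryl group would move the number beyond the scatter remains open. The true size of the pyrimidin-5-yl exchange also remains open, since compound 1 stands at a limit of the assay and not at a number: the limit of > 100000 nM in this assay, at which 1 of the 4 values shown sits.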